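A Methyl for a Methoxy in a Cytotoxicity Series

This account rests on a few compounds, and the source may have more. Where it says the series, first, only, none or still open, it means among the compounds named here.

Compound 1 `COC(=O)c1ccc(NCc2cncn2Cc2ccccc2OC)cc1-c1ccccc1` has been run in a toxicity assay on NIH3T3 cells (Mus musculus) for cytotoxicity, read by resazurin assay (a higher number here means that more compound is needed for the effect, a lower number that less compound is needed), yet in this assay compound 1 gives "not determined" (no result reported). Two related compounds set the scene. Compound 2 `O=C(OC1CCCCC1)c1ccc(NCc2cncn2Cc2ccc(-c3ccccc3)cc2)cc1-c1ccccc1` reaches only the limit of the assay, giving > 10000 nM in this assay. Compound 3 `c1ccc(-c2ccc(Cn3cncc3CNc3ccc(-c4ccccc4)c(-c4ccccc4)c3)cc2)cc1` likewise stops at the limit, giving > 10000 nM in this assay. The step between them, a step that the two limits leave unreadable from compound 2 to compound 3, therefore carries no readable size and no direction.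

Compound 4 `COC(=O)c1ccc(NCc2cncn2Cc2ccccc2C)cc1-c1ccccc1` differs from compound 1 in one place: methyl in place of methoxy on an aromatic carbon. No measured step touches this change, and compound 1 itself has no number in this assay, so nothing shown points up or down; the only guide is the limit of > 10000 nM in this assay, at which 2 of the 3 values shown sit. Compound 4 is therefore expected to give about 15000 nM in this assay, within a range of 5000 nM to 50000 nM, and the estimate most likely returns again as a limit rather than a number.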

Compound 4, half-maximal effective concentration: 10000 nM
Estimate against measurement, compound 4: 1.5-fold (0.18 log units) above; low and high end bracket the measured number.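

No step can be read between compound 1 and compound 4: in this assay compound 1 gives "not determined" (no result reported), and compound 4 has no partner to compare with. The compounds shown leave open whether methyl in place of methoxy changes the cytotoxicity at all, and in which direction.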